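The source may report more compounds than this note shows. Statements on the series, on what has been measured and on what is new or still open speak of the compounds shown alone.

Compound 1 `COc1ccccc1-c1ccc2ncn(-c3cc(OC)c(OC)c(OC)c3)c2c1` gives 5050 nM
Compound 2 `COc1cc(-n2cnc3ccc(-c4ccc(C(F)(F)F)cc4)cc32)cc(OC)c1OC` gives 890 nM

In a functional assay on SGC-7901 cells (Homo sapiens) for antiproliferative activity, read by MTT assay, with a stated time of 72 h (a lower number here means a stronger inhibitor, a higher number a weaker inhibitor), compound 2 holds the lower of the two numbers (890 nM), and no third value is available yet. Compound 3 `COc1cc(-n2cnc3ccc(-c4cccc(Cl)c4)cc32)cc(OC)c1OC` is unmeasured and carries 3-chlorophenyl in place of 4-(trifluoromethyl)phenyl on an aromatic carbon. The step of a 5.7-fold lower number from compound 1 to compound 2 (0.75 log units; beyond the scatter) is the only measured one at this place, modest but beyond the scatter. Among the compounds with values here, it shows that the number can move with the group here, but no measured compound carries 3-chlorophenyl, so the direction is weakly supported. Within the data shown here, with compound 2 the lower of only two values (890 nM), a small rise in this assay is expected, smaller than the measured step. Among the measured compounds shown here, the expected move is a 1.8-fold higher number from compound 2 to compound 3 (0.25 log units; within the scatter) and no larger step is assumed. Compound 3 is estimated at 1600 nM within an expected range of 450 nM to 5500 nM in this series.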

Compound 3, half-maximal inhibitory concentration: 1490 nM
Compound 3: middle estimate off by 1.1-fold (0.03 log units), on the high side; the measured number falls inside the stated range.
By their numbers in this assay, from the lowest: compounds 2 and 3 (each within the scatter of the next); then compound 1.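

In this assay the exchange of 4-(trifluoromethyl)phenyl for 3-chlorophenyl gives a 1.7-fold higher number from compound 2 to compound 3 (0.22 log units; within the scatter) and so does not separate these two groups at this aromatic carbon. With 3-chlorophenyl in place of 2-methoxyphenyl, the series shows a 3.4-fold lower number from compound 1 to compound 3 (0.53 log units; beyond the scatter) and thus a second step away from compound 1, which now stands apart from both compound 2 and compound 3 in this assay, although two points cannot define a trend. No measurement here bears on the reason for this grouping.

The compounds shown leave open how an aminomethyl or carboxylic acid substituent on this phenyl ring would behave. They also leave open whether the phenyl ring is needed at all, as an amine or a longer alkyl chain at the same carbon would test.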